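A few compounds are considered here, and "the series" means these few. Any claim that something is new, unique, unknown or untested is made for them only; others in the source may bear on it.

Measured in a functional assay on A549 cells (Homo sapiens) for antiproliferative activity, read by MTT assay, with a stated time of 24 h; a lower number here means a stronger inhibitor, a higher number a weaker inhibitor:
- Compound 1 `Cc1ccccc1NNC(=O)c1ccc(NS(=O)(=O)c2cnc(O)nc2O)cc1`: 14500 nM
- Compound 2 `Cc1cccc(NNC(=O)c2cccc(NS(=O)(=O)c3cnc(O)nc3O)c2)c1`: > 20000 nM

Compound 2 gives > 20000 nM, which is a limit of this assay and not a number. Compound 3 `O=C(NNc1ccccc1F)c1cccc(NS(=O)(=O)c2cnc(O)nc2O)c1` carries 2-fluorophenyl in place of 3-methylphenyl on an amine nitrogen. Going by the values given here, the only exact number nearby is compound 1 at 14500 nM, so weak activity is expected again. The expected step of an at least 1.1-fold lower number from compound 2 to compound 3 (0.04 log units; that floor lies within the scatter) in this assay is small, within the usual scatter. For compound 3 the estimated value is 18000 nM, with an expected range of 10000 nM to 30000 nM.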

Compound 3, half-maximal inhibitory concentration: 11100 nM
The estimate for compound 3 lay 1.6-fold (0.21 log units) above the measured number; measured number inside the range.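

Putting 2-fluorophenyl in place of 3-methylphenyl on this amine nitrogen turns a limit into a measured number, with an at least 1.8-fold lower number from compound 2 to compound 3 (0.25 log units; that floor lies within the scatter). That floor alone does not establish a real gain, and the true size of the step stays unknown because compound 2 has a limit and not a number: the limit of > 20000 nM in this assay, at which 1 of the 3 values shown sits.

The compounds shown do not separate the effect of adding fluorine from that of removing methyl. On these data alone, it also remains open how a plain phenyl or a chlorophenyl would behave on this nitrogen.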